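The compounds below may be only part of what the source reports. "The series", "measured", "known", "first", "only" and "open" are said of these compounds alone.

In a functional assay on HT-29 cells (Homo sapiens) for inhibition, read by CCK-8 assay, with a stated time of 24 h (a higher number here means a weaker inhibitor, a lower number a stronger inhibitor), compound 1 `Cc1cccc(-n2cc(-c3ccc(/C=C4\C(=O)Nc5ccccc54)cc3)nn2)c1` gives 3940 nM as its half-maximal inhibitory concentration. Compound 2 `O=C1Nc2ccccc2/C1=C/c1ccc(-c2cn(-c3cccc(Cl)c3)nn2)cc1` shows > 20000 nM as its reading, which is a limit of the assay and not a number. Among the compounds with values here, the one measured step, an at least 5.0-fold higher number from compound 1 to compound 2 (0.70 log units; beyond the scatter) for chloro in place of methyl, lies beyond the scatter. Compound 3 `N#Cc1cccc(-n2cc(-c3ccc(/C=C4\C(=O)Nc5ccccc54)cc3)nn2)c1` has cyano in place of chloro on an aromatic carbon. Within the data shown here, no measured step involves cyano, so the earlier step is only a loose guide. A modest move toward a lower number in this assay is expected, estimated as an at least 2.0-fold lower number from compound 2 to compound 3 (0.30 log units; that floor lies within the scatter) for this change. Compound 3 is expected at 10000 nM as an estimate, within 3000 nM to 30000 nM as its likely range.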

Compound 3, half-maximal inhibitory concentration: > 20000 nM
Compound 3: no number, only a limit; the forecaster's own chance of this, stated with the estimate: 40%; at least 2.0-fold (0.30 log units) between middle value and limit.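

In this assay compound 3 gives > 20000 nM, which is a limit of the assay and not a number. Cyano in place of methyl on this aromatic carbon, meta to a large group, gives an at least 5.0-fold higher number from compound 1 to compound 3 (0.70 log units; beyond the scatter), so a second replacement for methyl also ends up weaker. The step between the chloro and cyano compounds cannot be read because both readings stop at a limit: the limit of > 20000 nM in this assay, at which 2 of the 3 values shown sit.

As far as these compounds go, how far compound 2 and compound 3 each lie past that limit stays open. So does whether an ethyl group, a methoxy group or an amine at this position would keep a measurable reading.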